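Moving a Methoxy Group Across Two Related Cores

A few compounds are considered here, and "the series" means these few. Any claim that something is new, unique, unknown or untested is made for them only; others in the source may bear on it.

Compound 2 `COc1ccc2c(c1)C=C(C(=O)/C=C/c1ccccc1OC)CO2` and compound 1 `COc1ccc(/C=C/C(=O)C2=Cc3cc(OC)ccc3OC2)cc1` share one core. In a functional assay on HCT-116 cells (Homo sapiens) for cytotoxicity, read by crystal violet staining, with a stated time of 7 days (a lower number here means a stronger inhibitor, a higher number a weaker inhibitor), compound 2 gives 1620 nM and compound 1 gives 590 nM; the change 4-methoxyphenyl in place of 2-methoxyphenyl on a double-bonded chain carbon bound to a double-bonded chain carbon brought a 2.7-fold lower number from compound 2 to compound 1 (0.44 log units; beyond the scatter). Compound 3 `COc1ccc2c(c1)C=C(/C=C/C(=O)c1ccccc1OC)CO2` carries a second core; the difference between the two cores is not broken down here. In this assay compound 3 gives 1040 nM. Compound 4 `COc1ccc(C(=O)/C=C/C2=Cc3cc(OC)ccc3OC2)cc1` is related to compound 3 by 4-methoxyphenyl in place of 2-methoxyphenyl on a carbonyl carbon, the same kind of change as that between compound 2 and compound 1, though not the same: here the group sits on a carbonyl carbon whose other neighbours are a double-bonded chain carbon, rather than on a double-bonded chain carbon bound to a double-bonded chain carbon. Because of a 2.7-fold lower number from compound 2 to compound 1 (0.44 log units; beyond the scatter), the step expected in this assay is a 2.1-fold lower number from compound 3 to compound 4 (0.32 log units; beyond the scatter), kept a little smaller since the surroundings differ. Compound 4 is estimated at 500 nM, between 250 nM and 1000 nM.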

Compound 4, half-maximal inhibitory concentration: 7950 nM
The estimate for compound 4 lay 16-fold (1.20 log units) below the measured number, outside the stated range (above it).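

In this assay, 4-methoxyphenyl in place of 2-methoxyphenyl on a carbonyl carbon brought a 7.6-fold higher number from compound 3 to compound 4 (0.88 log units; beyond the scatter). The change therefore did not carry from one core to the other, and the two steps run in opposite directions: the same change on two cores in this assay, a 2.7-fold lower number (0.44 log units; beyond the scatter) from compound 2 to compound 1 and a 7.6-fold higher number (0.88 log units; beyond the scatter) from compound 3 to compound 4, 21-fold (1.32 log units) apart, beyond the scatter of two such steps. These four compounds do not show which feature of the two cores sets the steps apart, and a single pair on each core cannot say how any other change would carry over.

The compounds shown leave open whether an aminophenyl or hydroxyphenyl group in the same place would split the two cores in the same way. They also leave open whether an unsubstituted phenyl would do so.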